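A few compounds are considered here, and "the series" means these few. Any claim that something is new, unique, unknown or untested is made for them only; others in the source may bear on it.

Compound 1, `C[C@H]1[C@H](NCc2cccs2)C[C@H]2C[C@@H]1C2(C)C`, is the parent of this small set. Among the compounds with values here, in an ADME assay on MDCK cells (Canis lupus familiaris) for cytotoxicity, read by microscopy, with a stated time of 48 h (on this read-out lower numbers stand for higher toxicity in this test and higher numbers for lower toxicity in this test), compound 1 gives 25000 nM, the higher of the two numbers measured so far; its only neighbour is compound 2, `C[C@H]1[C@H](NCc2ccc(C(C)(C)C)s2)C[C@H]2C[C@@H]1C2(C)C`, which in this assay gives 780 nM. Within the data shown here, the one measured step, tert-butyl in place of hydrogen on an aromatic carbon, is a 32-fold lower number from compound 1 to compound 2 (1.51 log units; beyond the scatter).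

Compound 3, `CCCc1ccsc1CN[C@@H]1C[C@H]2C[C@@H]([C@H]1C)C2(C)C`, has not yet been measured. It differs from compound 1 by propyl in place of hydrogen on an aromatic carbon. The propyl group sits on a different ring carbon from the tert-butyl of compound 2 and is a smaller group, so the step to compound 2 bears on it only loosely: it shows that adding an alkyl group to this ring can lower the number sharply, but it does not tell how much a propyl at this place would do. A lower number than compound 1 is therefore expected, of moderate size, with the step estimated as a 6.3-fold lower number from compound 1 to compound 3 (0.80 log units; beyond the scatter). Compound 3 is expected to give about 4000 nM in this assay, with a likely range from 1000 nM to 16000 nM.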

Compound 3, minimum cytotoxic concentration: 50000 nM
Compound 3: middle estimate off by 13-fold (1.10 log units), on the low side; measured number outside the range, above it.
By their numbers in this assay, from the lowest: compound 2; then compounds 1 and 3 (each within the scatter of the next).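

Propyl in place of hydrogen on an aromatic carbon, next to the ring atom that bears a large group and two ring bonds from the ring sulfur, gives a 2.0-fold higher number from compound 1 to compound 3 (0.30 log units; within the scatter) in this assay and so leaves compound 3 not distinguishable from compound 1 on this read-out. The earlier step, a 32-fold lower number from compound 1 to compound 2 (1.51 log units; beyond the scatter) with tert-butyl at another ring carbon, had shown only that an alkyl group on this ring can go with a much lower number; this result shows that such a group does not always do so, and that this position accepts propyl with no step beyond the scatter. No measurement available here accounts for the contrast between the two steps.

The compounds shown leave open whether the group or its place separates these steps, since a tert-butyl at this position and a propyl at the carbon bearing tert-butyl in compound 2 do not appear among them. They also leave open how a methyl, a longer chain, an amine or a carboxylic acid at this position would read in this assay on the core of compound 1.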